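Ring swap on the carbonyl carbon: compound 2 to compound 4

This account rests on a few compounds, and the source may have more. Where it says the series, first, only, none or still open, it means among the compounds named here.

Three members of the series have numbers in a functional assay on UO-31 cells (Homo sapiens) for inhibition, read by sulforhodamine B assay, with a stated time of 48 h; a higher number here means a weaker inhibitor of growth, a lower number a stronger inhibitor of growth. Compound 1 `COc1cc(-c2cc(/C=C/C(=O)c3ccc(N)cc3)[nH]n2)cc(OC)c1OC` gives 2860 nM in this assay. Compound 2 `COc1ccc(C(=O)/C=C/c2cc(-c3cc(OC)c(OC)c(OC)c3)n[nH]2)cc1` gives 2840 nM. Compound 3 `COc1cc(C(=O)/C=C/c2cc(-c3cc(OC)c(OC)c(OC)c3)n[nH]2)cc(OC)c1OC` gives 2480 nM. Compound 2 stands second highest of the three, with compound 1 as its nearest neighbour and compound 3 as its furthest, and all three sit within the scatter of one another, so no order among them can be read. Going by the values given here, the one single-point step known, a 1.0-fold lower number from compound 1 to compound 2 (0.00 log units; within the scatter), swaps methoxy for amino on an aromatic carbon without moving the number.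

Compound 4 `COc1cc(-c2cc(/C=C/C(=O)c3ccc(F)c(F)c3)[nH]n2)cc(OC)c1OC` is not yet measured. Its change from compound 2 is 3,4-difluorophenyl in place of 4-methoxyphenyl on a carbonyl carbon. The step from compound 1 to compound 2 bears on it most directly, as it also alters a group on the aromatic ring that carries the change, and it was flat. Compound 3 and compound 2, which differ on the other aromatic ring, give numbers within the scatter of one another. Nothing measured here points to a move beyond the scatter. Compound 4 is therefore expected to land close to compound 2. The expected step is a 1.0-fold lower number from compound 2 to compound 4 (0.01 log units; within the scatter). The estimate for compound 4 is 2800 nM, in a range from 1400 nM to 5600 nM.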

Compound 4, concentration for total growth inhibition: 14200 nM
Compound 4: the middle estimate sits 5.1-fold (0.71 log units) below what was measured; measured number above the stated range.
By their numbers in this assay, from the lowest: compounds 3, 2 and 1 (each within the scatter of the next); then compound 4.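

In this assay, the group on the carbonyl carbon can move the number: a 5.0-fold higher number from compound 2 to compound 4 (0.70 log units; beyond the scatter), and a 5.0-fold higher number from compound 1 to compound 4 (0.70 log units; beyond the scatter), so 3,4-difluorophenyl gives a weaker inhibitor of growth than either 4-methoxyphenyl or 4-aminophenyl. Going by these compounds alone, the earlier step at this place, a 1.0-fold lower number from compound 1 to compound 2 (0.00 log units; within the scatter), showed only that those two groups are interchangeable here, not that the position accepts any aryl group without change. No supporting information bears on why the number rises with this ring swap.

The compounds shown leave open whether the shift follows from the loss of the methoxy or amino group or from the entry of the two fluorines, as compound 4 changes both at once. A plain phenyl, a monofluorophenyl or a chlorophenyl group on the same carbonyl carbon would help separate these readings and show whether the higher number belongs to fluorine in particular or to any ring lacking the methoxy or amino group.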